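Cyano substitution on the pyridyl ring of compound 1

This account rests on a few compounds, and the source may have more. Where it says the series, first, only, none or still open, it means among the compounds named here.

Measured so far:
compound 1 `c1cncc(N2C[C@H]3CCNC[C@H]32)c1` — 1400 nM
compound 2 `Clc1ccc(N2C[C@H]3CCNC[C@H]32)cn1` — 216 nM
compound 3 `COc1cc(N2C[C@@H]3CCNC[C@@H]32)cnc1Br` — 1690 nM

In a functional assay on HEK293 cells for agonist activity at Neuronal acetylcholine receptor; alpha4/beta2 (Homo sapiens), read by FLIPR (on this read-out higher numbers stand for an effect only at larger amounts of compound and lower numbers for an effect already at smaller amounts), compound 1 gives 1400 nM, the second highest of the three numbers; compound 3 lies within the scatter of it, while compound 2 sits well lower. Within the data shown here, the one single-point step known, a 6.5-fold lower number from compound 1 to compound 2 (0.81 log units; beyond the scatter), shows that a halogen on the shared core can lower the number considerably. Compound 4 `N#Cc1cncc(N2C[C@H]3CCNC[C@H]32)c1` differs from compound 1 by cyano in place of hydrogen on an aromatic carbon. Among the measured compounds shown here, no measured step covers a cyano group, and the chloro step in compound 2 concerns another substituent, so it serves only as a loose pointer. A modest lowering is expected, a 1.8-fold lower number from compound 1 to compound 4 (0.24 log units; within the scatter), with compound 4 estimated at 800 nM (range 250 nM to 2500 nM).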

Compound 4, half-maximal effective concentration: 1930 nM
Compound 4: middle estimate off by 2.4-fold (0.38 log units), on the low side, and the stated range covers the measured number.
By their numbers in this assay, from the lowest: compound 2; then compounds 1, 3 and 4 (each within the scatter of the next).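

In this assay, placing cyano on this aromatic carbon, two atoms from the ring nitrogen, gives a 1.4-fold higher number from compound 1 to compound 4 (0.14 log units; within the scatter), a step within the scatter, unlike the chloro step, a 6.5-fold lower number from compound 1 to compound 2 (0.81 log units; beyond the scatter). Adding a substituent to the aromatic ring of the shared core therefore does not by itself lower the number. No available evidence bears on this result. Still open, as far as these compounds go, is whether an amino group or a carboxylic acid on this same carbon would also stay within the scatter of compound 1. Also open, from the compounds shown here alone, is how chloro would behave on this carbon.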